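Series notes: replacing the silicon-bearing group of compound 3

The source may report more compounds than this note shows. Statements on the series, on what has been measured and on what is new or still open speak of the compounds shown alone.

Of the compounds shown here, three have been measured and one awaits measurement. Compound 1 `CC(C)=CCC[C@]1(C)/C=C/[C@@H](OC(=O)C=C(C)C)[C@](C)(O)/C=C/C(=O)/C(CCl)=C\C1` gives 610 nM in a functional assay on MCF7 cells (Homo sapiens) for antiproliferative activity, read by MTT assay, with a stated time of 48 h; on this read-out higher numbers stand for weaker inhibition and lower numbers for stronger inhibition. Compound 2 `CCN(CC)C/C1=C/C[C@](C)(CCC=C(C)C)/C=C/[C@@H](OC(=O)C=C(C)C)[C@](C)(O)/C=C/C1=O` gives 130 nM in this assay. Compound 3 `CC[Si](CC)(CC)C/C1=C/C[C@](C)(CCC=C(C)C)/C=C/[C@@H](OC(=O)C=C(C)C)[C@](C)(O)/C=C/C1=O` gives 3150 nM in this assay. Compound 3 stands at the highest number of the three, and both gaps lie beyond the scatter: a 5.2-fold higher number from compound 1 to compound 3 (0.71 log units; beyond the scatter), and a 24-fold higher number from compound 2 to compound 3 (1.38 log units; beyond the scatter).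

Compound 4 `CC(C)=CCC[C@]1(C)/C=C/[C@@H](OC(=O)C=C(C)C)[C@](C)(O)/C=C/C(=O)/C(C(=O)N(C)C)=C\C1` differs from compound 3 at the same part of the shared core: a group of 5 heavy atoms (3 carbon, 1 nitrogen, 1 oxygen; no ring) in place of a group of 8 heavy atoms (7 carbon, 1 silicon; no ring), on a double-bonded ring carbon. All three measured steps concern substitution at this one site and therefore bear on the change. Going from the chloro compound, a 4.7-fold lower number from compound 1 to compound 2 (0.67 log units; beyond the scatter); in contrast, a 5.2-fold higher number from compound 1 to compound 3 (0.71 log units; beyond the scatter); and between the two larger groups, a 24-fold higher number from compound 2 to compound 3 (1.38 log units; beyond the scatter). Both of the smaller groups measured at this site gave lower numbers than the silicon-bearing chain of compound 3, and the group entering in compound 4 is of comparable size to that of compound 2, though it carries an oxygen rather than a basic nitrogen chain. A lower number is therefore expected from compound 3 to compound 4, roughly undoing the rise seen in compound 3: a 5.3-fold lower number from compound 3 to compound 4 (0.72 log units; beyond the scatter). Compound 4 is estimated at 600 nM in this assay, with a range from 150 nM to 2500 nM.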

Compound 4, half-maximal inhibitory concentration: 3670 nM
Compound 4: the middle estimate sits 6.1-fold (0.79 log units) below what was measured; measured number above the stated range.
By their numbers in this assay, from the lowest: compound 2; then compound 1; then compounds 3 and 4 (each within the scatter of the next).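

In this assay, dimethylcarbamoyl and the silicon-bearing chain of compound 3 are not told apart, with a 1.2-fold higher number from compound 3 to compound 4 (0.07 log units; within the scatter) as the step, so the lower heavy-atom count of the entering group brings no gain at this double-bonded ring carbon. Dimethylcarbamoyl also stands well away from the other two groups, with a 28-fold higher number from compound 2 to compound 4 (1.45 log units; beyond the scatter) against (diethylamino)methyl and a 6.0-fold higher number from compound 1 to compound 4 (0.78 log units; beyond the scatter) against chloromethyl, which leaves compound 2 as the only clear low point among the four compounds. A carbonyl bound directly to the ring carbon cannot be singled out as the feature that goes with the higher numbers, as compound 3 goes against that reading with no carbonyl in its group. No data at hand bear on the reason for these differences.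

Open, as far as these compounds go, is whether the low number of compound 2 carries over to other amines on the same carbon, such as (dimethylamino)methyl or morpholinomethyl. Also open, from the compounds shown here alone, is whether a methylcarbamoyl group or a carboxylic acid at this ring carbon would read differently from dimethylcarbamoyl.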